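Series notes: trifluoromethyl and dichloro benzoyl variants

The source may hold more compounds than are shown below. What is called first, only, known or untested is meant among the compounds shown, and "the series" means these compounds.

Of the compounds shown here, three have been measured in a functional assay on HepG2 cells (Homo sapiens) for inhibition, read by MTT assay, with a stated time of 72 h; on this read-out higher numbers stand for weaker inhibition and lower numbers for stronger inhibition. Compound 1 `CN(C(=O)NC(=O)c1cccc(C(F)(F)F)c1)c1nc(C(F)(F)F)c(C(=O)N/N=C/c2cccc(C(F)(F)F)c2)s1` gives 5.79 ug/mL in this assay. Compound 2 `CN(C(=O)NC(=O)c1ccc(Cl)cc1Cl)c1nc(C(F)(F)F)c(C(=O)N/N=C/c2ccc(C(F)(F)F)cc2)s1` gives 12.4 ug/mL, and compound 3 `COc1ccc(/C=N/NC(=O)c2sc(N(C)C(=O)NC(=O)c3c(F)cccc3F)nc2C)cc1` gives 22.7 ug/mL. Compound 2 thus holds the second highest of the three numbers; its gap to compound 3 lies within the scatter, so the two are not to be ordered, while its gap to compound 1 lies beyond the scatter, compound 1 showing the lower number.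

The next compound, compound 4 `CN(C(=O)NC(=O)c1ccc(C(F)(F)F)cc1)c1nc(C(F)(F)F)c(C(=O)N/N=C/c2ccc(C(F)(F)F)cc2)s1`, differs from compound 2 in one place: 4-(trifluoromethyl)phenyl in place of 2,4-dichlorophenyl on a carbonyl carbon. Among the measured compounds shown here, no measured pair in the set isolates this change, so no step size is on hand for it; compound 1 and compound 2 differ at several places at once and cannot serve as a clean reference.

The expectation for compound 4 is a step of a 1.4-fold lower number from compound 2 to compound 4 (0.14 log units; within the scatter) that stays small, pointing toward a somewhat lower number but not clearly beyond the scatter. Compound 4 is estimated at 9 ug/mL, with a likely range from 4 ug/mL to 20 ug/mL.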

Compound 4, half-maximal inhibitory concentration: > 100 ug/mL
Compound 4 was reported as a limit; the forecaster's own chance of this, stated with the estimate: 5%; at least 11-fold (1.04 log units) between middle value and limit.
By their numbers in this assay, from the lowest: compound 1; then compounds 2 and 3 (each within the scatter of the next). At a limit, above all of these: compound 4.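

This position, on a carbonyl carbon whose other neighbour is the amide-type nitrogen, proves sensitive to the aryl group it carries: 4-(trifluoromethyl)phenyl in place of 2,4-dichlorophenyl gives an at least 8.0-fold higher number from compound 2 to compound 4 (0.90 log units; beyond the scatter) in this assay. For compound 4, the entry > 100 ug/mL is a limit of the assay and not a number, so the step fixes only a minimum size for the change: the limit of > 100 ug/mL in this assay, at which 1 of the 4 values shown sits. The earlier compounds shown here offered no pair isolating this position, and this swap alone now takes the series from a measurable value to the limit.

Going by these compounds, how far compound 4 lies past its limit stays open. Also open, on these data alone, is whether the loss follows the departure of the two chlorines or the arrival of trifluoromethyl, a question that 4-chlorophenyl or unsubstituted phenyl on this carbonyl carbon would address.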